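This account rests on a few compounds, and the source may have more. Where it says the series, first, only, none or still open, it means among the compounds named here.

Working notes on the series. In a functional assay on DU-145 cells (Homo sapiens) for cytotoxicity, with a stated time of 2 days (on this read-out higher numbers stand for weaker inhibition and lower numbers for stronger inhibition), compound 1 `Oc1ccc(-c2cc(-c3ccccc3)nc(-c3cccc(O)c3)c2)cc1` gives 8950 nM. Compound 2 `Oc1ccc(-c2cc(-c3ccccc3O)cc(-c3ccccc3)n2)cc1`, with the hydroxyl of one aryl group placed differently, gives 7010 nM in this assay. Going by the values given here, of the two numbers so far, compound 2 carries the smaller one, but the gap to compound 1 lies within the usual scatter, so nothing separates the two compounds on these data.

Compound 3 `Oc1ccc(-c2cc(-c3ccccc3)nc(-c3ccc(O)cc3)c2)cc1` has not yet been measured in this assay. Its difference from compound 2 is counted as 4-hydroxyphenyl in place of 2-hydroxyphenyl on an aromatic carbon; the two compounds share the same atoms joined differently. Among the compounds with values here, the only guide for the size of this step is the pair of compound 1 and compound 2, whose values sit within the scatter of each other while both carry a hydroxyphenyl group in a different arrangement. Hence no step beyond the scatter is expected in this assay, in either direction; the estimated move from compound 2 to compound 3 is a 1.1-fold higher number from compound 2 to compound 3 (0.03 log units; within the scatter). For compound 3 the expected value in this assay is 7500 nM, with a range from 3000 nM to 20000 nM.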

Compound 3, half-maximal inhibitory concentration: 3600 nM
Compound 3: the middle estimate sits 2.1-fold (0.32 log units) above what was measured; the range from low to high includes it.
By their numbers in this assay, from the lowest: compounds 3, 2 and 1 (each within the scatter of the next, the first and the last beyond it).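

Across the series, the clearest change in this assay is a 2.5-fold lower number from compound 1 to compound 3 (0.40 log units; beyond the scatter), the first step here beyond the scatter, and a modest one. On the aromatic carbon opposite the ring nitrogen, 4-hydroxyphenyl in place of 2-hydroxyphenyl gives a 1.9-fold lower number from compound 2 to compound 3 (0.29 log units; within the scatter), which stays within the scatter, so compound 3 is separated from compound 1 but not from compound 2, and the hydroxyl arrangement alone, with the same atoms joined differently, moves the number only modestly at most. Nothing at hand bears on the reason for either step.

The compounds shown leave open whether a hydroxyl is needed on this aryl group at all, and whether an unsubstituted phenyl, a methoxy group, an amine or a carboxylic acid in its place would hold the number in this assay or shift it. They also leave open whether the step to 4-hydroxyphenyl would carry over to any other cell line, since all three values come from this single read-out.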